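This account rests on a few compounds, and the source may have more. Where it says the series, first, only, none or still open, it means among the compounds named here.

Three compounds share one core and differ only in the aryl group attached to it. Compound 1 `CCOc1ccc(-c2ccc3ncn(-c4cc(OC)c(OC)c(OC)c4)c3c2)cc1` gives 1710 nM in a functional assay on MCF7 cells (Homo sapiens) for antiproliferative activity, read by MTT assay, with a stated time of 72 h; a higher number here means a weaker inhibitor, a lower number a stronger inhibitor. Compound 2 `COc1ccccc1-c1ccc2ncn(-c3cc(OC)c(OC)c(OC)c3)c2c1` gives 1750 nM, and the step of a 1.0-fold higher number from compound 1 to compound 2 (0.01 log units; within the scatter) shows that exchanging one alkoxyphenyl for another left the number essentially unchanged. Compound 3 `COc1cc(-n2cnc3ccc(-c4cccc(O)c4)cc32)cc(OC)c1OC` gives 350 nM, the lowest of the three numbers, and both steps toward it, a 4.9-fold lower number from compound 1 to compound 3 (0.69 log units; beyond the scatter) and a 5.0-fold lower number from compound 2 to compound 3 (0.70 log units; beyond the scatter), are modest but lie beyond the scatter, so the hydroxyphenyl stands apart from the two alkoxyphenyls.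

Compound 4 `COc1cc(-n2cnc3ccc(-c4ccc(O)cc4)cc32)cc(OC)c1OC` has not yet been measured. Its difference from compound 3 is 4-hydroxyphenyl in place of 3-hydroxyphenyl on an aromatic carbon. Among the measured compounds shown here, none of the measured steps tests this particular exchange, since all three measured compounds carry a different aryl group from one another rather than the same substituent at a shifted place. For the measured compounds named here, the only clue is that compound 1 and compound 2, which carry alkoxy groups at two different places, gave numbers within the scatter of each other, which makes a large swing seem unlikely. A step of about a 1.4-fold higher number from compound 3 to compound 4 (0.15 log units; within the scatter) is therefore expected, small and possibly within the scatter. Compound 4 is thus estimated to give 500 nM, with a plausible range from 200 nM to 1500 nM.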

Compound 4, half-maximal inhibitory concentration: 4160 nM
The estimate for compound 4 lay 8.3-fold (0.92 log units) below the measured number; measured number above the stated range.
By their numbers in this assay, from the lowest: compound 3; then compounds 1 and 2 (each within the scatter of the next); then compound 4.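

Moving the hydroxyl around the ring, with the atoms themselves unchanged, produces the largest step in this small set: a 12-fold higher number from compound 3 to compound 4 (1.08 log units; beyond the scatter) in this assay. The 3-hydroxyphenyl and the 4-hydroxyphenyl therefore cannot be treated as interchangeable, and the place of the hydroxyl matters more here than the switch between the two alkoxyphenyl groups did. The hydroxyl alone also does not guarantee a lower number, as the two hydroxyphenyl compounds fall on opposite sides of the alkoxyphenyl compounds: a 2.4-fold higher number from compound 2 to compound 4 (0.38 log units; beyond the scatter), and removing the ethyl from the oxygen of the 4-ethoxyphenyl gives a 2.4-fold higher number from compound 1 to compound 4 (0.39 log units; beyond the scatter); nothing available here explains why the place of the hydroxyl makes this difference.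

Among the compounds shown here, with only one pair of compounds testing a change of place, it remains open whether this sensitivity belongs to the hydroxyl or would also appear with an amine or a carboxylic acid on the same ring. It is also unclear whether a methoxy group at the two places compared here would separate the numbers as widely as the hydroxyl does.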